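The source may report more compounds than this note shows. Statements on the series, on what has been measured and on what is new or still open speak of the compounds shown alone.

Among the measured compounds shown here, compound 2 `Cc1ccc(-c2ccc([N+](=O)[O-])cc2)n1-c1ccc(-c2nc3ccc(F)cc3s2)cc1` gives the highest of the two numbers so far in an ADME assay on MCF-10A cells (Homo sapiens) for cytotoxicity, read by MTT assay, with a stated time of 72 h (on this read-out higher numbers stand for weaker inhibition and lower numbers for stronger inhibition), at 39000 nM; its nearest neighbour is compound 1 `Cc1ccc(-c2ccc(C)n2-c2ccc(-c3nc4ccc(F)cc4s3)cc2)cc1`, which in this assay gives 33600 nM, and the step of a 1.2-fold higher number from compound 1 to compound 2 (0.06 log units; within the scatter) lies within the scatter. Compound 3 `COc1ccc2nc(-c3ccc(-n4c(C)ccc4-c4ccc([N+](=O)[O-])cc4)cc3)sc2c1` differs from compound 2 by methoxy in place of fluoro on an aromatic carbon, on an aromatic carbon of a six-membered aromatic ring of carbon only, part of a fused system of two rings, meta and para to a fused ring. For the measured compounds named here, no measured step touches this part of the shared core; the single step known, from compound 1 to compound 2, changes the aryl substituent on the other side and stays within the scatter. Compound 3 is therefore expected to sit close to compound 2, with an estimated step of a 1.0-fold higher number from compound 2 to compound 3 (0.01 log units; within the scatter) that does not rise beyond the scatter. The estimate for compound 3 in this assay is 40000 nM, with a range from 15000 nM to 100000 nM.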

Compound 3, half-maximal inhibitory concentration: 34900 nM
The estimate for compound 3 lay 1.1-fold (0.06 log units) above the measured number; the range from low to high includes it.
By their numbers in this assay, from the lowest: compounds 1, 3 and 2 (each within the scatter of the next).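

In this assay, among the compounds shown here, the step of a 1.1-fold lower number from compound 2 to compound 3 (0.05 log units; within the scatter) is the first reading at this place, on an aromatic carbon of a six-membered aromatic ring of carbon only, meta to a fused ring and para to a fused ring, and it shows that methoxy in place of fluoro stays within the scatter. With the earlier nitro for methyl change, the two places tried so far have both left this read-out within the scatter, and no listed compound goes against this. Nothing at hand explains this result.

Going by these compounds, whether an amine, a carboxylic acid or a longer chain at this place would give a step beyond the scatter stays open. So does whether methoxy in place of fluoro would read the same on compound 1, which carries methyl where compound 2 carries nitro.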